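This account rests on a few compounds, and the source may have more. Where it says the series, first, only, none or still open, it means among the compounds named here.

Measured so far:
Compound 1, `CCCCCCCCCCCCCC(=O)NCC(C)(C)CC1=C(O)C(=O)c2ccccc2C1=O`, in a functional assay on KB cells (Homo sapiens) for cytotoxicity, read by resazurin assay, with a stated time of 3 days (a lower number here means a stronger inhibitor, a higher number a weaker inhibitor), gives 25100 nM.
Compound 2, `CCCCCCCCCCCCCCCC(=O)NCC(C)(C)CC1=C(O)C(=O)c2ccccc2C1=O`, gives 5120 nM.
Compound 3, `CCCCCCCCCCCCCCCC(=O)OCC(C)(C)CC1=C(O)C(=O)c2ccccc2C1=O`, gives 27100 nM.

Compound 1 and compound 2 share one core and differ only in the length of the chain on the amide. The change is ethyl in place of hydrogen on a saturated chain carbon, ten or more bonds along the chain from a carbonyl carbon, and it brought a 4.9-fold lower number from compound 1 to compound 2 (0.69 log units; beyond the scatter). Compound 3 carries an ester in place of that amide; how its core differs from that of compound 1 is not broken down here, and its value stands close to that of compound 1.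

Compound 4, `CCCCCCCCCCCCCCCCCC(=O)OCC(C)(C)CC1=C(O)C(=O)c2ccccc2C1=O`, is not yet measured. Set beside compound 3, it shows (ethyl in place of hydrogen on a saturated chain carbon, ten or more bonds along the chain from a carbonyl carbon), the same change that led from compound 1 to compound 2, on the same kind of place. If the ester series answers as the amide series did, a drop of similar size is expected, resting on a 4.9-fold lower number from compound 1 to compound 2 (0.69 log units; beyond the scatter) for compound 2. For compound 4 the expected step is a 4.5-fold lower number from compound 3 to compound 4 (0.65 log units; beyond the scatter), and its value in this assay is estimated at 6000 nM, roughly between 2500 nM and 15000 nM.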

Compound 4, half-maximal inhibitory concentration: 76700 nM
Estimate against measurement, compound 4: 13-fold (1.11 log units) below; the whole stated range lies below it.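

In this assay, the ester series did not answer as the amide series did: with ethyl in place of hydrogen on a saturated chain carbon, ten or more bonds along the chain from a carbonyl carbon, the result is a 2.8-fold higher number from compound 3 to compound 4 (0.45 log units; beyond the scatter) and not a drop. Set side by side, the same change moved the number in opposite directions on the two cores, by more than repeated measurement would explain: the same change on two cores in this assay, a 4.9-fold lower number (0.69 log units; beyond the scatter) from compound 1 to compound 2 and a 2.8-fold higher number (0.45 log units; beyond the scatter) from compound 3 to compound 4, 14-fold (1.14 log units) apart, beyond the scatter of two such steps. This shows that the step seen on the amide core cannot be carried over to the ester core in this series, but with a single pair on each core it does not show why, since the ester pair starts from the chain length at which the amide pair ends, so the link and the chain length are not separated.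

The compounds shown leave open how a longer chain behaves on the amide core and a shorter chain on the ester core. They also leave open what an amine or a carboxylic acid would do in place of the amide or ester.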